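A few compounds are considered here, and "the series" means these few. Any claim that something is new, unique, unknown or untested is made for them only; others in the source may bear on it.

Measured compounds in a functional assay on cells (Tumor Cell line, Homo sapiens) for cytotoxicity; on this read-out higher numbers stand for weaker inhibition of growth and lower numbers for stronger inhibition of growth:
- compound 1, `COc1cccc(-c2cc(O)c3c(C)cc(C)nc3n2)c1`: 646 nM
- compound 2, `COc1ccccc1-c1cc(O)c2cccnc2n1`: 40700 nM
- compound 3, `COc1cccc(-c2cc(O)c3c(C)ccnc3n2)c1`: 58.9 nM

Compound 3 gives the lowest number of the three in this assay, and both of its gaps to the others are beyond the scatter, so it is the most potent of the measured set. Compound 2 stands highest; its gap to compound 1 and to compound 3 are each beyond the scatter. How the core of compound 2 differs from that of compound 3 is not broken down here.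

One change is seen within the measured set: methyl in place of hydrogen on an aromatic carbon. Its step is an 11-fold higher number from compound 3 to compound 1 (1.04 log units; beyond the scatter), a large loss of potency.

Compound 4, `COc1ccccc1-c1cc(O)c2c(C)ccnc2n1`, is not yet measured. It differs from compound 2 by methyl in place of hydrogen on an aromatic carbon. Within the data shown here, this is the same kind of change as the one from compound 3 to compound 1, but not the same: there the methyl enters next to the ring nitrogen, meta to a fused ring, meta to a methyl group and para to a fused ring, whereas here it enters ortho to a fused ring, meta to a fused ring and opposite the ring nitrogen. The measured step therefore transfers only loosely. Among the measured compounds shown here, compound 3, which already carries a methyl ortho to the fused ring, gives 58.9 nM, but no measured pair isolates that methyl, so its effect is unknown. For compound 4 a small step, a 2.0-fold lower number from compound 2 to compound 4 (0.31 log units; beyond the scatter), is expected, giving an estimate of 20000 nM with a range from 5000 nM to 60000 nM.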

Compound 4, concentration for 50% growth inhibition: 2820 nM
For compound 4 the middle estimate is 7.1-fold (0.85 log units) above the measured one; the whole stated range lies above it.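

In this assay, methyl in place of hydrogen on an aromatic carbon gives a 14-fold lower number from compound 2 to compound 4 (1.16 log units; beyond the scatter), a large gain in potency, whereas the earlier case gives an 11-fold higher number from compound 3 to compound 1 (1.04 log units; beyond the scatter), a large loss. The effect of this change therefore does not carry as a single value from one core to another in this series, and here even its direction reverses: the same change on two cores in this assay, an 11-fold higher number (1.04 log units; beyond the scatter) from compound 3 to compound 1 and a 14-fold lower number (1.16 log units; beyond the scatter) from compound 2 to compound 4, 160-fold (2.20 log units) apart, beyond the scatter of two such steps The two steps differ both in where the methyl enters and in the core that receives it, so this pair cannot show whether the place, the rest of the core or both set the outcome, and it gives no general rule for a methyl on the shared ring system.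

Still open is whether the gain seen for a methyl opposite the ring nitrogen also holds with the methoxy group placed as in compound 3, as no pair shown isolates that methyl on that core. Also open, from the compounds shown here alone, is how other groups at that place compare with methyl, such as an ethyl group, a chlorine atom, an amine or a carboxylic acid.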